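Ester to Allylamide on a Polyene Chain: Lipophilicity Forecast

The source may report more compounds than this note shows. Statements on the series, on what has been measured and on what is new or still open speak of the compounds shown alone.

Measured compounds:
compound 1 `CCCOC(=O)/C=C(C)/C=C/CC(C)CCCC(C)C` gives 7.28
compound 2 `COC(=O)/C=C(C)/C=C/CC(C)CCCC(C)(C)OC` gives 5
compound 3 `CCOC(=O)/C=C(C)/C=C/CC(C)CCCC(C)CC` gives 7.81

Three compounds sharing one polyene ester core have been characterised in a physicochemical assay for lipophilicity; a higher number here means a more lipophilic compound, a lower number a more polar compound. Compound 1 stands second highest of the three: compound 3 lies above it by a margin beyond the usual scatter, and compound 2 lies well below it, also beyond the scatter. No pair among these three differs in only one place, so no single step can be read directly from them.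

The next compound, compound 4 `C=CCNC(=O)/C=C(C)/C=C/CC(C)CCCC(C)C`, has not yet been measured in this assay. Relative to compound 1 the change is allylamino in place of propoxy on a carbonyl carbon. Swapping propoxy for allylamino on the carbonyl carbon, which exchanges a hydrogen-bond acceptor for a hydrogen-bond donor, is expected to lower the partition coefficient by an amount beyond the scatter, an estimated step of a number 1.38 log units lower from compound 1 to compound 4 (beyond the scatter). Compound 4 is therefore estimated at 5.9, with a range from 5.2 to 6.6.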

Compound 4, partition coefficient: 5.23
The estimate for compound 4 lay 0.67 log units above the measured number; the measured number falls inside the stated range.
By their numbers in this assay, from the lowest: compounds 2 and 4 (each within the scatter of the next); then compound 1; then compound 3.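

For the compounds shown here, at the carbonyl carbon of the shared core, the exchange of propoxy for allylamino gives the first single-place step: in this assay, it is a number 2.05 log units lower from compound 1 to compound 4 (beyond the scatter), and it counts as large. This step arises even though the leaving and entering groups each hold 4 heavy atoms, so this position responds strongly to a change that leaves that count the same. The change also replaces an oxygen link with a nitrogen link, adds the amide hydrogen and brings in a double bond, and nothing available accounts for the size of the step.

On these data alone, how much of the step goes with the double bond and how much with the amide hydrogen remains open, a question that propylamino on the same carbonyl carbon would address. A dimethylamino group there would likewise show what the step becomes without the amide hydrogen.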